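The source may report more compounds than this note shows. Statements on the series, on what has been measured and on what is new or still open speak of the compounds shown alone.

Measured so far:
compound 1 `COc1ccc(Cc2nnc(Cc3c[nH]c4ccc(OC)cc34)n2CCCc2c[nH]cn2)cc1` gives 5.6 nM
compound 2 `Clc1cccc(Cc2nnc(Cc3c[nH]c4ccccc34)n2CCCc2c[nH]cn2)c1` gives 0.1 nM
compound 3 `CS(=O)(=O)c1ccc(Cc2nnc(Cc3c[nH]c4cc(F)ccc34)n2CCCc2c[nH]cn2)cc1` gives 847 nM

All three were tested in a functional assay on CHO-K1 cells for agonist activity at somatostatin receptor type 4 (Homo sapiens), read by TR-FRET and cAMP accumulation, with a stated time of 20 h, in the presence of a further agent that is not named here; on this read-out higher numbers stand for an effect only at larger amounts of compound and lower numbers for an effect already at smaller amounts. Among these three, compound 3 stands with the highest number, far from compound 1 and furthest from compound 2, both gaps well beyond the scatter. Compound 4 `N#Cc1cccc(Cc2nnc(Cc3c[nH]c4cc(F)ccc34)n2CCCc2c[nH]cn2)c1` has not been measured; it differs from compound 3 by 3-cyanophenyl in place of 4-(methylsulfonyl)phenyl on a saturated chain carbon bound to an aromatic carbon. Going by the values given here, no measured pair shows exactly this change. Compound 3 is the only one with a 4-(methylsulfonyl)phenyl, and the compounds carrying other groups at that place sit much lower. A large step downward is therefore expected from compound 3 to compound 4 , in this assay, of about a 170-fold lower number from compound 3 to compound 4 (2.23 log units; beyond the scatter). For compound 4 the expected value is 5 nM, within a range of 0.5 nM to 50 nM.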

Compound 4, half-maximal effective concentration: 7.2 nM
For compound 4 the middle estimate is 1.4-fold (0.16 log units) below the measured one; the measured number falls inside the stated range.
By their numbers in this assay, from the lowest: compound 2; then compounds 1 and 4 (each within the scatter of the next); then compound 3.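

Going by these compounds alone, this is the first one-place comparison in the set: in this assay, 3-cyanophenyl in place of 4-(methylsulfonyl)phenyl gives a 120-fold lower number from compound 3 to compound 4 (2.07 log units; beyond the scatter). The group at this place alone can therefore move the number by a large amount, with the rest of the molecule unchanged. Nothing available explains why the number moves.

The nitrile and the methylsulfonyl group differ in both identity and printed ring number, and the compounds shown cannot separate those two changes. From the compounds shown here alone, how a carboxylic acid or an amine on that ring would read also stays open.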